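Pyridin-4-yl in Place of Pyridin-3-yl on a Shared Core

The source may report more compounds than this note shows. Statements on the series, on what has been measured and on what is new or still open speak of the compounds shown alone.

Measured so far:
compound 1, `C[C@H](Nc1nc(N)nc(N)c1C#N)c1nn(-c2cccc(S(C)(=O)=O)c2)c2cc(F)ccc12`, 14%
compound 2, `C[C@H](Nc1ncnc2[nH]cnc12)c1nn(-c2cccnc2)c2ccc(F)cc12`, -22%
compound 3, `C[C@H](Nc1ncnc2[nH]cnc12)c1nn(-c2cccnc2)c2cc(F)ccc12`, 8%

All three compounds were tested in a functional assay on Bel-7402 cells (Homo sapiens) for inhibition, read by sulforhodamine B assay, with a stated time of 72 h, tested at 10 uM; a lower number here means less inhibition, a higher number more inhibition at the concentration tested (going by the name of the read-out). Compound 3 stands second of the three numbers; its value and that of compound 1 lie within the usual scatter of each other, so no order between them can be claimed, while compound 2 sits clearly lower, beyond the scatter. Compound 4, `C[C@H](Nc1ncnc2[nH]cnc12)c1nn(-c2ccncc2)c2cc(F)ccc12`, has not yet been measured. It differs from compound 3 in one place: pyridin-4-yl in place of pyridin-3-yl on an aromatic nitrogen. Among the compounds with values here, no measured pair shows the effect of this change. A step of little size, none beyond the scatter, is expected from compound 3 to compound 4 in this assay, namely a number 3 percentage points lower from compound 3 to compound 4 (within the scatter). Compound 4 is therefore estimated at 5%, within a range of -15% to 25%.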

Compound 4, a percentage reported as inhibition, at one concentration (the size of the read-out at that concentration, not a potency): 16%
Compound 4: middle estimate off by 11 percentage points, on the low side; the range from low to high includes it.
By their numbers in this assay, from the lowest: compound 2; then compounds 3, 1 and 4 (each within the scatter of the next).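

In this assay, within the data shown here, the swap to pyridin-4-yl gives a number 8 percentage points higher from compound 3 to compound 4 (within the scatter) and offers the first direct reading at this position. On this aromatic nitrogen, the two pyridine attachments cannot be told apart at the single concentration tested. Nothing measured here offers an explanation for the result.

Still open, as far as these compounds go, is whether a plain phenyl ring, or a pyridine ring carrying an amine, would give a number beyond the scatter at this position. From the compounds shown here alone, it is also open whether the two pyridines would remain indistinguishable at other concentrations.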